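This account rests on a few compounds, and the source may have more. Where it says the series, first, only, none or still open, it means among the compounds named here.

In an ADME assay on HeLa cells (Homo sapiens) for cytotoxicity, read by MTT assay, with a stated time of 72 h (on this read-out lower numbers stand for stronger inhibition of growth and higher numbers for weaker inhibition of growth), compound 1 `COc1ccc(/C=C\C(=O)N2N=C(c3ccncc3)OC2c2c[nH]c3ccccc23)cc1` reaches only the assay's limit, > 30 ug/mL.
In this assay compound 2 `O=C(/C=C\c1cccc(F)c1)N1N=C(c2ccncc2)OC1c1c[nH]c2ccccc12` also gives a limit, > 30 ug/mL.

Both values sit at the same limit (the limit of > 30 ug/mL in this assay, at which 2 of the 2 values shown sit), so compound 2 stands level with compound 1 and the step that the two limits leave unreadable from compound 1 to compound 2 cannot be read. Compound 3 `O=C(/C=C\c1ccc(Br)cc1)N1N=C(c2ccncc2)OC1c1c[nH]c2ccccc12` differs from compound 2 by 4-bromophenyl in place of 3-fluorophenyl on a double-bonded chain carbon bound to a double-bonded chain carbon. Going by the values given here, no measured step bears on this change, so no shift beyond the scatter in this assay is expected in either direction. The step that the limit leaves unreadable from compound 2 to compound 3 is expected to be small. Compound 3 is expected at 40 ug/mL, between 15 ug/mL and 120 ug/mL.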

Compound 3, concentration for 50% growth inhibition: > 30 ug/mL
Compound 3 gave a limit, no number; the forecaster's own chance of this, stated with the estimate: 75%; the middle value does not contradict the limit.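

No step can be read among compound 1, compound 2 and compound 3, because all three stop at a limit and give no number: the limit of > 30 ug/mL in this assay, at which 3 of the 3 values shown sit.
The compounds shown leave open whether any other group in this place would give a readable number in this assay rather than a limit.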